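Tetrazole substituent changes in a pituitary cell series

The compounds below may be only part of what the source reports. "The series", "measured", "known", "first", "only" and "open" are said of these compounds alone.

Measured so far:
compound 1 `Cn1nnc(-c2ccccc2-c2ccc(CN3C(=O)[C@H](NC(=O)CC(C)(C)N)CCc4ccccc43)cc2)n1` gives 0.3 uM
compound 2 `CC(O)Cn1nnc(-c2ccccc2-c2ccc(CN3C(=O)[C@H](NC(=O)CC(C)(C)N)CCc4ccccc43)cc2)n1` gives 0.05 uM
compound 3 `Cn1nnnc1-c1ccccc1-c1ccc(CN2C(=O)[C@H](NC(=O)CC(C)(C)N)CCc3ccccc32)cc1` gives 0.5 uM

All three were run in a functional assay (Pituitary gland cell) with Rattus norvegicus as the target; a higher number here means that more compound is needed for the effect, a lower number that less compound is needed. Compound 3 has the highest number of the three; its nearest neighbour is compound 1, where the step is a 1.7-fold higher number from compound 1 to compound 3 (0.22 log units; within the scatter) and so within the scatter, and its furthest is compound 2, where the step is a 10-fold higher number from compound 2 to compound 3 (1.00 log units; beyond the scatter).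

The next compound, compound 4 `CC(C)(N)CC(=O)N[C@@H]1CCc2ccccc2N(Cc2ccc(-c3ccccc3-c3nnn(CC(=O)O)n3)cc2)C1=O`, differs from compound 3 in one place: 2-(carboxymethyl)-2H-tetrazol-5-yl in place of 1-methyl-1H-tetrazol-5-yl on an aromatic carbon. The change sits on an aromatic carbon of a six-membered aromatic ring of carbon only, ortho to a large group.

Among the compounds with values here, two measured steps bear on this. Moving the methyl between the two tetrazole nitrogens, a 1.7-fold higher number from compound 1 to compound 3 (0.22 log units; within the scatter), did not move the number beyond the scatter. Putting a 2-(2-hydroxypropyl) chain on the tetrazole instead of the 1-methyl, seen as the reverse of a 10-fold higher number from compound 2 to compound 3 (1.00 log units; beyond the scatter), lowered the number by a modest but clear amount. The carboxymethyl chain in compound 4 is again a short polar chain on the same ring nitrogen, so a lower number than compound 3 is expected, of a size like a 5.0-fold lower number from compound 3 to compound 4 (0.70 log units; beyond the scatter). Compound 4 is therefore estimated at 0.1 uM in this assay, with a range from 0.03 uM to 0.4 uM.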

Compound 4, concentration for half-maximal effect: 0.2 uM
Compound 4: the middle estimate sits 2.0-fold (0.30 log units) below what was measured; the range from low to high includes it.
By their numbers in this assay, from the lowest: compound 2; then compounds 4, 1 and 3 (each within the scatter of the next, the first and the last beyond it).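

In this assay, the carboxymethyl chain on the 2H-tetrazole gives a step beyond the scatter against the 1-methyl-1H-tetrazol-5-yl group (a 2.5-fold lower number from compound 3 to compound 4 (0.40 log units; beyond the scatter)), yet carboxy in place of hydrogen on the saturated chain carbon bound to an aromatic nitrogen stays within the scatter (a 1.5-fold lower number from compound 1 to compound 4 (0.18 log units; within the scatter)), so this change cannot be told apart from the plain 2-methyl-2H-tetrazol-5-yl group. The same chain carbon does distinguish between its substituents, since carboxy and 1-hydroxyethyl are separated by a step beyond the scatter (a 4.0-fold higher number from compound 2 to compound 4 (0.60 log units; beyond the scatter)), and the low number of compound 2 is therefore not a result of any short chain at this place but is so far tied to the 1-hydroxyethyl group alone. Nothing available explains this difference between the two chains.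

Open, as far as these compounds go, is whether an amine or a methyl ester at the end of the chain would fall with compound 2 or with compound 4, and whether a longer chain would change the picture. Also open, from the compounds shown here alone, is whether the 1H-tetrazole form seen in compound 3 would respond to a 2-hydroxypropyl chain in the same way.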